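A few compounds are considered here, and "the series" means these few. Any claim that something is new, unique, unknown or untested is made for them only; others in the source may bear on it.

Of the compounds shown here, two sharing one core have so far been measured in an ADME assay on MDBK cells (Bos taurus) for cytotoxicity, read by MTT assay, with a stated time of 96 h; a higher number here means that more compound is tolerated, a lower number that less compound is tolerated. Compound 1 `Nc1ccc(-c2nc3cc(Cl)c(Cl)cc3[nH]2)cc1` gives 7500 nM. Compound 2 `O=C(CN1CCCC1)Nc1ccc(-c2nc3cc(Cl)c(Cl)cc3[nH]2)cc1`, which carries ((pyrrolidin-1-yl)methyl)carbonyl in place of hydrogen on a nitrogen on an aromatic ring, gives 16000 nM. That single step, a 2.1-fold higher number from compound 1 to compound 2 (0.33 log units; beyond the scatter), is the only one measured, and it leaves compound 2 with the higher of the two numbers, with compound 1 standing a modest distance below it.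

Compound 3 `O=C(CN1CCCCC1)Nc1ccc(-c2nc3cc(Cl)c(Cl)cc3[nH]2)cc1` has not yet been measured. It differs from compound 2 in one place: piperidin-1-yl in place of pyrrolidin-1-yl on a saturated chain carbon bound to a carbonyl carbon. For the measured compounds named here, no measured step involves an exchange of this kind; the step from compound 1 to compound 2 added a whole group where hydrogen stood, whereas here one saturated ring gives way to a closely related one. Going by the values given here, with nothing directly comparable to draw on, and the only known step being modest, the expected step is no change at the digits printed from compound 2 to compound 3 (within the scatter), which sits within the usual scatter. Compound 3 is therefore estimated at 16000 nM in this assay, with a range from 8000 nM to 32000 nM.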

Compound 3, half-maximal cytotoxic concentration: 45000 nM
Estimate against measurement, compound 3: 2.8-fold (0.45 log units) below; measured number above the stated range.
By their numbers in this assay, from the lowest: compound 1; then compound 2; then compound 3.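

In this assay, the identity of the ring at the end of the side chain now proves to count: piperidin-1-yl in place of pyrrolidin-1-yl, on a saturated chain carbon bound to a carbonyl carbon, gives a 2.8-fold higher number from compound 2 to compound 3 (0.45 log units; beyond the scatter), so one extra ring carbon is enough to move the number beyond the scatter. The earlier pair showed only that one acylated side chain could raise the number, whereas the complete ((piperidin-1-yl)methyl)carbonyl group in place of hydrogen on a nitrogen on an aromatic ring gives a 6.0-fold higher number from compound 1 to compound 3 (0.78 log units; beyond the scatter), and both side chains shown now stand on the more tolerated side of the parent compound. No measurement shown here accounts for the difference in tolerance that follows the change of ring.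

The compounds shown leave open whether the number would keep rising with the seven-membered azepan-1-yl ring, or whether an oxygen atom in the ring, as in morpholin-4-yl, would preserve it. Also open, on these data alone, is what an open-chain diethylamino group, or a longer chain linking the carbonyl to the piperidin-1-yl ring, would do in this assay.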